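Substituents on the aromatic nitrogen of the shared core

The compounds below may be only part of what the source reports. "The series", "measured", "known", "first", "only" and "open" are said of these compounds alone.

Measured so far:
compound 1, `O=C(c1ccn2c1CSC2c1cccnc1)c1c[nH]c2cc(-c3ccc(F)cc3)ccc12`: 6.4 mg/kg
compound 2, `CN(C)C(=O)n1cc(C(=O)c2ccn3c2CSC3c2cccnc2)c2ccc(OCc3ccccc3)cc21`: 3.3 mg/kg
compound 3, `CN(C)C(=O)Cn1cc(C(=O)c2ccn3c2CSC3c2cccnc2)c2ccc(-c3ccc(F)cc3)cc21`: 0.12 mg/kg

In a functional assay on the whole organism for inhibition, with Rattus norvegicus as the target (on this read-out higher numbers stand for an effect only at larger amounts of compound and lower numbers for an effect already at smaller amounts), compound 1 gives 6.4 mg/kg, the highest of the three numbers. Compound 2 gives 3.3 mg/kg, a number within the scatter of compound 1, and compound 2 differs from compound 1 in more than one place, so nothing is read from that pair. Going by the values given here, compound 3 gives 0.12 mg/kg, and the single-point step a 53-fold lower number from compound 1 to compound 3 (1.73 log units; beyond the scatter) is the only measured step that bears on the present question.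

Compound 4, `O=C(O)CCn1cc(C(=O)c2ccn3c2CSC3c2cccnc2)c2ccc(-c3ccc(F)cc3)cc21`, is not yet measured. It differs from compound 1 by 2-carboxyethyl in place of hydrogen on an aromatic nitrogen, on the same aromatic nitrogen that carries the entering group in compound 3. The entering group is not the same as in compound 3, so the large step seen there is taken only as a direction, not as a size. Compound 4 is therefore expected to show a lower number than compound 1, with an expected step of a 6.4-fold lower number from compound 1 to compound 4 (0.81 log units; beyond the scatter), well short of the step to compound 3. The estimate for compound 4 in this assay is 1 mg/kg, with a range from 0.15 mg/kg to 6.4 mg/kg.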

Compound 4, dose for half-maximal effect: 5.1 mg/kg
Compound 4: middle estimate off by 5.1-fold (0.71 log units), on the low side; measured number inside the range.
By their numbers in this assay, from the lowest: compound 3; then compounds 2, 4 and 1 (each within the scatter of the next).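

In this assay a group on the aromatic nitrogen does not by itself bring the large step seen earlier: 2-carboxyethyl in place of hydrogen gives a 1.3-fold lower number from compound 1 to compound 4 (0.10 log units; within the scatter) and so leaves compound 4 level with compound 1. Exchange of dimethylcarbamoyl for carboxymethyl on the saturated chain carbon bound to that nitrogen gives a 43-fold higher number from compound 3 to compound 4 (1.63 log units; beyond the scatter), which ties the large step to the identity of the entering group, not merely to the presence of a substituent. No measured information here explains this difference between the two entering groups.

An amine or a methyl ester at the end of the same chain would show how widely the end group can vary at this position. A dimethylamide on a longer chain would separate the effect of chain length from that of the end group, a question that compound 2 cannot settle as it differs from the others in more than one place.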